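Swapping the Pyrazole Substituent for a Fused Carbon Ring

The compounds below may be only part of what the source reports. "The series", "measured", "known", "first", "only" and "open" are said of these compounds alone.

Of the compounds shown here, three sharing one core have been measured in an assay on cells for displacement of a labelled ligand from Glucagon receptor (Homo sapiens), in the presence of a further agent that is not named here; a higher number here means a weaker inhibitor, a lower number a stronger inhibitor. Compound 1 `CCCC(Oc1ccc(-n2cc(OC)cn2)cc1)c1ccc(C(=O)NCCC(=O)O)cc1` gives 4400 nM, compound 2 `CCCC(Oc1ccc(-n2cc(C(F)(F)F)c(C)n2)cc1)c1ccc(C(=O)NCCC(=O)O)cc1` gives 1100 nM, and compound 3 `CCCC(Oc1ccc(-n2cc(C#N)cn2)cc1)c1ccc(C(=O)NCCC(=O)O)cc1` gives 4100 nM. Compound 3 thus stands second highest of the three; its number sits within the scatter of compound 1, while compound 2 lies clearly lower.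

Compound 4 `CCCC(Oc1ccc(-n2cc3c(n2)CCCC3)cc1)c1ccc(C(=O)NCCC(=O)O)cc1` differs from compound 3 at one place: a group of 9 heavy atoms (7 carbon, 2 nitrogen; one five-membered aromatic ring with 2 hetero atoms, one six-membered non-aromatic ring of carbon only) in place of a group of 7 heavy atoms (4 carbon, 3 nitrogen; one five-membered aromatic ring with 2 hetero atoms), on an aromatic carbon. For the measured compounds named here, two measured steps bear on this. The step of a 1.1-fold lower number from compound 1 to compound 3 (0.03 log units; within the scatter) shows that exchanging one small substituent on the pyrazole for another hardly moves this assay. The step of a 3.7-fold higher number from compound 2 to compound 3 (0.57 log units; beyond the scatter), however, shows that a pyrazole carrying two carbon-based groups gives a clearly lower number than the cyano-bearing one. The entering group of compound 4 also carries carbon on the pyrazole, so a modest drop of that size is expected, though not more.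

For compound 4 the estimated outcome is 1500 nM, with a likely range of 500 nM to 4500 nM, meaning an expected step of a 2.7-fold lower number from compound 3 to compound 4 (0.44 log units; beyond the scatter).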

Compound 4, inhibition constant: 690 nM
The estimate for compound 4 lay 2.2-fold (0.34 log units) above the measured number; the range from low to high includes it.
By their numbers in this assay, from the lowest: compounds 4 and 2 (each within the scatter of the next); then compounds 3 and 1 (each within the scatter of the next).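

In this assay, the fused group of compound 4 performs on a par with the 3-methyl-4-(trifluoromethyl)-1H-pyrazol-1-yl group, since the exchange gives only a small difference (a 1.6-fold lower number from compound 2 to compound 4 (0.20 log units; within the scatter)). Against the pyrazoles bearing a cyano or a methoxy group, the same fused group gives clearly lower numbers (a 5.9-fold lower number from compound 3 to compound 4 (0.77 log units; beyond the scatter); a 6.4-fold lower number from compound 1 to compound 4 (0.80 log units; beyond the scatter)), so among these compounds a low number at this position does not require a trifluoromethyl group. Nothing available here explains why these groups differ in this way.

Open, as far as these compounds go, is how much depends on the fused ring itself, as opposed to simple carbon substituents on the pyrazole, such as a single methyl or an ethyl group. Also open, from the compounds shown here alone, is whether a seven-membered carbon ring, or an amine on the fused ring, would keep the number this low.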